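The compounds below may be only part of what the source reports. "The series", "measured", "known", "first", "only" and "open" are said of these compounds alone.

Working notes on the sulfonamide series. Compound 1 `Cc1cccc(S(=O)(=O)Nc2ccc3oc(-c4ccccc4)nc3c2)c1` carries a 3-methylphenyl group on the sulfonyl sulfur. In an assay on cells for inhibition of HSP60/HSP10 (Homo sapiens), with a stated time of 60 min (a lower number here means a stronger inhibitor, a higher number a weaker inhibitor), compound 1 gives > 100000 nM, which is a limit of the assay and not a number. Compound 2 `COc1cccc(S(=O)(=O)Nc2ccc3oc(-c4ccccc4)nc3c2)c1`, with methoxy in place of methyl on an aromatic carbon, gives > 100000 nM in this assay, again only a limit. Compound 3 `CS(=O)(=O)Nc1ccc2oc(-c3ccccc3)nc2c1`, with methyl on the sulfonyl sulfur, gives > 100000 nM in this assay, likewise a limit. So the whole set sits at the limit of > 100000 nM in this assay, at which 3 of the 3 values shown sit, and no step among the three can be sized: a step that the two limits leave unreadable from compound 1 to compound 2, a step that the two limits leave unreadable from compound 1 to compound 3, a step that the two limits leave unreadable from compound 2 to compound 3.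

Compound 4 `O=S(=O)(Nc1ccc2oc(-c3ccccc3)nc2c1)c1cccc(O)c1` is the untested member. The change from compound 3 is 3-hydroxyphenyl in place of methyl on a sulfonyl sulfur. The two measured steps that touch the group on the sulfonyl sulfur, a step that the two limits leave unreadable from compound 1 to compound 3 and a step that the two limits leave unreadable from compound 2 to compound 3, bear on it, yet both are unreadable because of the limit of > 100000 nM in this assay, at which 3 of the 3 values shown sit. Neither aryl sulfonamide measured so far gives a number, and the 3-hydroxyphenyl group of compound 4 differs from those aryl groups only in the substituent on its ring. No direction can be read from the data, so the expectation is no readable step, a number no higher from compound 3 to compound 4 (the limit leaves the size open). Compound 4 is therefore estimated at 100000 nM in this assay, between 20000 nM and 300000 nM, most likely reported again as a limit.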

Compound 4, half-maximal inhibitory concentration: 76000 nM
The estimate for compound 4 lay 1.3-fold (0.12 log units) above the measured number, within the range that was stated.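

Working notes, continued. In this assay compound 4 is the only member shown to give a number, 76000 nM, and this turns the earlier unreadable comparisons into floors: an at least 1.3-fold lower number from compound 3 to compound 4 (0.11 log units; that floor lies within the scatter), an at least 1.3-fold lower number from compound 2 to compound 4 (0.11 log units; that floor lies within the scatter) and an at least 1.3-fold lower number from compound 1 to compound 4 (0.11 log units; that floor lies within the scatter). Among the groups shown on the sulfonyl sulfur, only 3-hydroxyphenyl gives a value inside the range of the assay, while the methyl, 3-methylphenyl and 3-methoxyphenyl compounds do not, although each floor lies within the scatter and so does not by itself establish a real gain. None of the three steps has a readable size, because the other compounds remain at the limit of the assay: the limit of > 100000 nM in this assay, at which 3 of the 4 values shown sit.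

On these data alone, how far compounds 1, 2 and 3 actually lie from compound 4 stays open, so the true size of replacing the methyl of compound 2 with hydrogen on that oxygen is unknown. As far as these compounds go, it is also open whether an amine or a carboxylic acid on the aromatic ring in place of hydroxy would give a number in this assay, or whether the effect is confined to hydroxy.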